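The compounds below may be only part of what the source reports. "The series", "measured", "known", "first", "only" and "open" are said of these compounds alone.

All numbers below come from an assay on cell membranes for displacement of a labelled ligand from Adrenergic receptor alpha-1 (Rattus norvegicus); a lower number here means a stronger inhibitor, a higher number a weaker inhibitor.

Measured so far:
compound 1 `Cc1ccc2c(C3CCN(CCN4CCNC4=O)CC3)cn(-c3ccc(F)cc3)c2c1` gives 24 nM
compound 2 `O=C1NCCN1CCN1CCC(c2cn(-c3ccc(F)cc3)c3cc(Cl)ccc23)CC1` gives 9.6 nM
compound 3 `Cc1ccc2c(C3CCN(CCN4CCN(C(C)C)C4=O)CC3)cn(-c3ccccc3)c2c1` gives 120 nM

Compound 1 and compound 2 differ in a single place: chloro in place of methyl on an aromatic carbon. The step from this change is a 2.5-fold lower number from compound 1 to compound 2 (0.40 log units; beyond the scatter). Compound 3 shows the highest number of the three. How its core differs from the core of compound 1 is not broken down here.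

Compound 4 `CC(C)N1CCN(CCN2CCC(c3cn(-c4ccccc4)c4cc(Cl)ccc34)CC2)C1=O` has not yet been measured. Relative to compound 3 the change is chloro in place of methyl on an aromatic carbon. The place lines of the two changes read the same word for word, so this is the same change, made a second time on a different core.

Among the measured compounds shown here, with only the one measured instance of this change to go on, the expectation for compound 4 is a step of about the same size as the earlier one, roughly a 2.5-fold lower number from compound 3 to compound 4 (0.40 log units; beyond the scatter); this rests on a 2.5-fold lower number from compound 1 to compound 2 (0.40 log units; beyond the scatter). For the measured compounds named here, the single precedent keeps the range wide. Compound 4 is therefore estimated at 48 nM, with an expected span from 20 nM to 110 nM.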

Compound 4, half-maximal inhibitory concentration: 39 nM
Beside the measured number, compound 4's estimate is 1.2-fold (0.09 log units) above it; the range from low to high includes it.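

In this assay, chloro in place of methyl on an aromatic carbon again lowers the number on the second core, with a 3.1-fold lower number from compound 3 to compound 4 (0.49 log units; beyond the scatter). Set beside the first instance, the two steps agree in direction and do not differ in size: the same change on two cores in this assay, a 2.5-fold lower number (0.40 log units; beyond the scatter) from compound 1 to compound 2 and a 3.1-fold lower number (0.49 log units; beyond the scatter) from compound 3 to compound 4, 1.2-fold (0.09 log units) apart, within the scatter of two such steps. This supports carrying the change between these two cores, but two instances on two cores give no general rule for the series, and the steps alone do not explain why the change lowers the number or show whether the other differences between the cores can ever alter its effect.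

The compounds shown leave open whether other groups on the same aromatic carbon, such as fluoro, methoxy or nitrile, would give a step in the same direction as chloro. Also open, on these data alone, is whether the step would persist on a core with a longer chain in place of isopropyl, or with an amine on the phenyl ring.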